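Methyl in place of fluoro on compound 2

This account rests on a few compounds, and the source may have more. Where it says the series, first, only, none or still open, it means among the compounds named here.

Of the compounds shown here, two have been measured so far in a physicochemical assay for lipophilicity, read by HPLC (a higher number here means a more lipophilic compound, a lower number a more polar compound), and their values are these.

- compound 1 `Cc1ccc(CNC(=O)C(CC(C)O)N(C)CCC=C(c2sccc2C)c2sccc2C)cc1` gives 6.15
- compound 2 `Cc1ccsc1C(=CCCN(C)C(CCN)C(=O)NCc1ccc(F)cc1)c1sccc1C` gives 6.45

Compound 2 stands within the usual scatter of compound 1, so these two numbers do not separate them. Among the compounds with values here, the next compound is compound 3 `Cc1ccc(CNC(=O)C(CCN)N(C)CCC=C(c2sccc2C)c2sccc2C)cc1` and its one difference from compound 2 is methyl in place of fluoro on an aromatic carbon with methyl in place of fluoro on an aromatic carbon, para to a large group. Within the data shown here, no measured pair here differs in one place, so the data offer no step to go by. In this assay a small upward step is expected, close to the size of the scatter. The estimated step is a number 0.15 log units higher from compound 2 to compound 3 (within the scatter) and it remains an expectation until measured. Compound 3 is estimated at 6.6 in this assay (expected range 6.25 to 6.95).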

Compound 3, partition coefficient: 6.61
Beside the measured number, compound 3's estimate is 0.01 log units below it; the measured number falls inside the stated range.
By their numbers in this assay, from the lowest: compounds 1, 2 and 3 (each within the scatter of the next, the first and the last beyond it).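

In this assay, methyl in place of fluoro on an aromatic carbon, para to a large group, gives a number 0.16 log units higher from compound 2 to compound 3 (within the scatter), so on this one pair the exchange of 4-fluorobenzyl for 4-methylbenzyl does not separate the two compounds. Within the data shown here, the pair that does separate lies on the chain: aminomethyl in place of 1-hydroxyethyl on a saturated chain carbon gives a number 0.46 log units higher from compound 1 to compound 3 (beyond the scatter), the first step here that stands clear of the scatter. Nothing available accounts for either step.

Each change is seen on a single pair, so neither can be read as a general rule. The compounds shown leave open how chloro or trifluoromethyl would read on that aromatic carbon, and how a carboxylic acid or a longer amine chain would read in place of the aminomethyl.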